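Benzimidazole series: a trifluoromethyl analogue of compound 3

The source may report more compounds than this note shows. Statements on the series, on what has been measured and on what is new or still open speak of the compounds shown alone.

Measured compounds:
compound 1, `Cc1cccc(Cn2c(OC3CCN(C(=O)c4ccco4)CC3)nc3ccccc32)c1`: 68.3%
compound 2, `Cc1cccc(Cn2c(CN3CCN(C(=O)C4CCCC4)CC3)nc3ccccc32)c1`: 67.5%
compound 3, `O=C(C1CC1)N1CCN(Cc2nc3ccccc3n2Cc2cccc(F)c2)CC1`: 27.2%

Of the compounds shown here, three have been tested in an assay on isolated protein for inhibition of aldehyde dehydrogenase 1A1 (Homo sapiens), read by spectrophotometry, tested at 10 uM; on this read-out higher numbers stand for more inhibition at the one concentration tested (going by the name of the read-out) and lower numbers for less inhibition. Compound 1 gives 68.3% and compound 2 gives 67.5%, two numbers that lie within the usual scatter of each other. Compound 3, with 27.2%, stands lowest of the three; its nearest neighbour is compound 2, whose number is higher by an amount beyond the scatter, and compound 1 lies further still, also beyond the scatter.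

Compound 4, `O=C(C1CC1)N1CCN(Cc2nc3ccccc3n2Cc2ccc(C(F)(F)F)cc2)CC1`, has not yet been measured in this assay. It differs from compound 3 in one place: 4-(trifluoromethyl)phenyl in place of 3-fluorophenyl on a saturated chain carbon bound to an aromatic nitrogen.

Within the data shown here, no pair of measured compounds differs in just this way, so the data give no step on which to lean. Among the measured compounds shown here, compound 3 is the only compound carrying a fluorine-bearing group on that saturated chain carbon, and the two compounds with a different group there sit far above it. Compound 4 is therefore expected to move upward from compound 3 by a moderate amount, a number 14.8 percentage points higher from compound 3 to compound 4 (beyond the scatter), though a change within the scatter in either direction cannot be excluded. The estimate for compound 4 in this assay is 42%, with a range from 15% to 68%.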

Compound 4, a percentage reported as inhibition, at one concentration (the size of the read-out at that concentration, not a potency): 37%
The estimate for compound 4 lay 5 percentage points above the measured number; low and high end bracket the measured number.
By their numbers in this assay, from the lowest: compounds 3 and 4 (each within the scatter of the next); then compounds 2 and 1 (each within the scatter of the next).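

In this assay, among these compounds, the exchange of 3-fluorophenyl for 4-(trifluoromethyl)phenyl on a saturated chain carbon bound to an aromatic nitrogen gives a number 9.8 percentage points higher from compound 3 to compound 4 (within the scatter) and is thus the first single-place step at this position, which the earlier compounds, differing from one another in more than one place, could not provide. The position takes the entering group, with 10 heavy atoms against 7 for the group it replaces, without a change that can be told from the usual scatter, so this exchange on its own does not shift the read-out measurably. Nothing available speaks to why the two groups read alike.

The step exchanges one whole group for another, so the compounds shown do not separate the kind of substituent from its place on the phenyl ring, as 3-(trifluoromethyl)phenyl or 4-fluorophenyl would. Also open, on these data alone, is what a different kind of group on that ring, such as an amine or a carboxylic acid, would do in this assay at this position.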